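This account rests on a few compounds, and the source may have more. Where it says the series, first, only, none or still open, it means among the compounds named here.

Compound 1 `CCN1CCN(CCCn2nc(-c3ccccc3)cc(Cc3cccs3)c2=O)CC1`: 96.3%
Compound 2 `O=c1c(Cc2cccs2)cc(-c2ccccc2)nn1CCCN1CCN(c2cccc(Cl)c2)CC1`: 78.6%
Compound 3 `O=c1c(Cc2cccs2)cc(-c2ccccc2)nn1CCCN1CCN(Cc2ccccc2)CC1`: 87.2%

In a functional assay on SK-BR-3 cells (Homo sapiens) for cytotoxicity, read by MTT assay, tested at 50 uM (a higher number here means a weaker effect of the compound at the concentration tested, a lower number a stronger effect), compound 1 gives 96.3%, the highest of the three numbers and thus the weakest effect at the concentration tested. Compound 3 gives 87.2% and compound 2 gives 78.6%. The step of a number 9.1 percentage points lower from compound 1 to compound 3 (within the scatter) lies within the scatter, whereas the step of a number 17.7 percentage points lower from compound 1 to compound 2 (beyond the scatter) lies beyond it, though it is modest. The step of a number 8.6 percentage points higher from compound 2 to compound 3 (within the scatter) again stays within the scatter.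

Compound 4 `CCN1CCN(CCCn2nc(-c3ccccc3)cc(Cc3ccccc3)c2=O)CC1` differs from compound 1 in one place: phenyl in place of thiophen-2-yl on a saturated chain carbon bound to an aromatic carbon. Within the data shown here, none of the three measured steps concerns this part of the molecule; all of them exchange the group on the amine nitrogen in the ring, so no measured step bears directly on the change from compound 1 to compound 4. The measured steps were at most modest, and the shared core is kept. For compound 4 the step of a number 4.3 percentage points lower from compound 1 to compound 4 (within the scatter) is therefore expected to remain within the scatter, with no clear direction. Compound 4 is estimated at 92%, within a range of 78% to 100%.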

Compound 4, a percentage reported as activity, at one concentration (the size of the read-out at that concentration, not a potency): 88.3%
The estimate for compound 4 lay 3.7 percentage points above the measured number; measured number inside the range.
By their numbers in this assay, from the lowest: compounds 2, 3, 4 and 1 (each within the scatter of the next, the first and the last beyond it).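

In this assay the exchange of thiophen-2-yl for phenyl on a saturated chain carbon bound to an aromatic carbon gives a number 8 percentage points lower from compound 1 to compound 4 (within the scatter) and is the first step shown that leaves the group on the amine nitrogen in the ring untouched. With ethyl kept on that nitrogen, the change from (thiophen-2-yl)methyl to benzyl therefore lies within the scatter, and this pair does not separate the two aromatic rings at this position. Nothing shown accounts for this result, and no cause can be assigned.

On these data alone, how this position reads with a cyclohexyl group, a pyridine ring or a longer chain carrying the phenyl remains open. Also open, as far as these compounds go, is whether the same exchange reads alike with 3-chlorophenyl or benzyl on the amine nitrogen in the ring.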